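The source may hold more compounds than are shown below. What is called first, only, known or untested is meant among the compounds shown, and "the series" means these compounds.

Compound 3 `O=C1COc2ccc(-c3nn(-c4ccc(Cl)cc4)cc3-c3ccccc3)cc2N1` is one of three compounds that share a core carrying a phenyl group and a halogenated aryl ring. In a functional assay on MV4-11 cells (Homo sapiens) for cytotoxicity, read by colorimetric assay and MTT assay, with a stated time of 3 days, tested at 1 uM (a lower number here means a stronger effect, a higher number a weaker effect of the compound at the concentration tested), compound 3 gives 108%, level with compound 1 `COc1ccc(-c2nc(-c3ccccc3)c(-c3ccc4c(c3)NC(=O)CO4)[nH]2)cc1`, which gives 108%, and with compound 2 `O=C1COc2ccc(-c3nn(-c4ccc(Br)cc4)cc3-c3ccccc3)cc2N1`, which gives 108%. Going by the values given here, the only measured step, no change at the digits printed from compound 2 to compound 3 (within the scatter), exchanged one halogen for another on the aryl ring and stayed within the scatter. Compound 4 `O=C1COc2ccc(-c3nn(-c4cc(Cl)cc(Cl)c4)cc3-c3ccccc3)cc2N1` differs from compound 3 by 3,5-dichlorophenyl in place of 4-chlorophenyl on an aromatic nitrogen. That one step bears on the change, since it also altered the halogen pattern of the same ring without effect, so no step beyond the scatter is expected. Compound 4 is therefore estimated at 105%, between 90% and 115%, an expected step of a number 3 percentage points lower from compound 3 to compound 4 (within the scatter).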

Compound 4, a percentage reported as activity, at one concentration (the size of the read-out at that concentration, not a potency): 105%
Compound 4: middle estimate and measured number agree at the digits printed; the range from low to high includes it.
By their numbers in this assay, from the lowest: compounds 4, 1, 2 and 3 (each within the scatter of the next).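

At this aromatic nitrogen, the earlier step had only exchanged one halogen for another, whereas 3,5-dichlorophenyl brings a second chlorine and a new halogen pattern to the ring, and this assay still shows only a number 3 percentage points lower from compound 3 to compound 4 (within the scatter). The comparison with 4-bromophenyl reads the same, with a number 3 percentage points lower from compound 2 to compound 4 (within the scatter), so across these three aryl groups the read-out does not leave the scatter. No evidence is available to explain this result. The compounds shown leave open whether an amine or a carboxylic acid on this aryl ring, in place of the halogens, would move the read-out in this assay beyond the scatter.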